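A few compounds are considered here, and "the series" means these few. Any claim that something is new, unique, unknown or untested is made for them only; others in the source may bear on it.

Of the compounds shown here, three sharing one core have been measured in a functional assay on MCF7 cells (Homo sapiens) for antiproliferative activity, read by MTT assay, with a stated time of 72 h; on this read-out higher numbers stand for weaker inhibition and lower numbers for stronger inhibition. Compound 1 `Cc1cc(NCCN(C)C)nc2ccc(NC(=O)c3ccc(Cl)c(Cl)c3)cc12` gives 2550 nM. Within the data shown here, compound 3 `Cc1cc(N2CCCCC2)nc2ccc(NC(=O)c3ccc(Cl)c(Cl)c3)cc12` gives 31100 nM, and the only single-place step among the measured compounds, a 12-fold higher number from compound 1 to compound 3 (1.09 log units; beyond the scatter), alters the group on the aromatic carbon rather than anything on the amide side. Compound 2 `CCN1CCN(c2cc(C)c3cc(NC(=O)c4ccc(Br)cc4)ccc3n2)CC1` gives 5940 nM, which places it second highest of the three numbers, with compound 1 nearest at a lower number beyond the scatter and compound 3 furthest at a higher number beyond the scatter.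

Compound 4 `CCN1CCN(c2cc(C)c3cc(NC(=O)c4ccccc4OC)ccc3n2)CC1` has not yet been measured. It differs from compound 2 by 2-methoxyphenyl in place of 4-bromophenyl on a carbonyl carbon. Among the measured compounds shown here, no measured step alters the group on the carbonyl carbon, so the step from compound 1 to compound 3 does not bear on this change directly, and nothing measured shows how far such a change moves the number. The step from compound 2 to compound 4 is therefore expected to be modest, a 1.3-fold higher number from compound 2 to compound 4 (0.13 log units; within the scatter), with a wide range. Compound 4 is estimated at 8000 nM, between 2500 nM and 25000 nM.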

Compound 4, half-maximal inhibitory concentration: 13200 nM
Compound 4: middle estimate off by 1.7-fold (0.22 log units), on the low side; the measured number falls inside the stated range.
By their numbers in this assay, from the lowest: compound 1; then compound 2; then compound 4; then compound 3.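

The exchange of 4-bromophenyl for 2-methoxyphenyl on a carbonyl carbon whose other neighbour is an amide-type nitrogen gives, in this assay, a 2.2-fold higher number from compound 2 to compound 4 (0.35 log units; beyond the scatter). Among these compounds, this shows that the group on the carbonyl carbon also moves the number, whereas the earlier compounds offered a single-place step only on the aromatic carbon, a 12-fold higher number from compound 1 to compound 3 (1.09 log units; beyond the scatter), which was large where this one is modest. Nothing measured here explains the shift.

The step alters the substituent and its location on the ring together, so 4-methoxyphenyl or 2-bromophenyl on the same carbonyl carbon would be needed to tell those two changes apart. From the compounds shown here alone, it also remains open whether 2-methoxyphenyl would give a similar step alongside (2-(dimethylamino)ethyl)amino on the aromatic carbon, and how an unsubstituted phenyl would read.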